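Thiourea series: cytotoxicity on MT4 cells

This account rests on a few compounds, and the source may have more. Where it says the series, first, only, none or still open, it means among the compounds named here.

Measured so far:
compound 1, `Fc1ccccc1NC(=S)Nc1cccc(C(F)(F)F)c1`: 47000 nM
compound 2, `CC[C@H]1CC[C@H](c2ccc(NC(=S)Nc3cccc(C(F)(F)F)c3)cc2)CC1`: 39000 nM

Both compounds share the thiourea linked to the trifluoromethyl-bearing phenyl and are assessed in an ADME assay on MT4 cells (Homo sapiens) for cytotoxicity; a higher number here means that more compound is tolerated, a lower number that less compound is tolerated. Compound 1 gives 47000 nM, compound 2 gives 39000 nM; the gap between the two lies within the usual scatter, so neither can be set above the other and compound 1 simply stands together with compound 2 at the only level seen so far in this assay.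

Compound 3, `FC(F)(F)c1cccc(NC(=S)NCc2ccco2)c1`, is not yet measured. It differs from compound 1 in one place: (furan-2-yl)methyl in place of 2-fluorophenyl on an amide-type nitrogen. Among the measured compounds shown here, no step between measured compounds bears on this kind of exchange, and the two numbers known do not separate from each other, so there is no basis for expecting a move beyond the scatter in either direction. The step from compound 1 to compound 3 in this assay is therefore expected to be small, a 1.0-fold lower number from compound 1 to compound 3 (0.02 log units; within the scatter), in effect none beyond the scatter. Compound 3 is estimated at 45000 nM, with a range from 20000 nM to 100000 nM.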

Compound 3, half-maximal cytotoxic concentration: 43000 nM
Beside the measured number, compound 3's estimate is 1.0-fold (0.02 log units) above it, and the stated range covers the measured number.
By their numbers in this assay, from the lowest: compounds 2, 3 and 1 (each within the scatter of the next).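

Notes on the position: in this assay, placing (furan-2-yl)methyl where 2-fluorophenyl stood on the amide-type nitrogen gives a 1.1-fold lower number from compound 1 to compound 3 (0.04 log units; within the scatter) as the only single-place step available so far in the series. At this nitrogen, then, one six-membered aromatic ring of carbon only can give way to one five-membered aromatic ring with 1 hetero atom, with a hydrogen-bond acceptor entering by the count, and the read-out does not separate from that of the parent beyond the scatter. Nothing measured here offers an explanation for this result, so the observation stands without a cause.

From the compounds shown here alone, both of these exchanged groups are aromatic rings of similar heavy-atom size, so it remains open whether the same level of tolerance holds at this nitrogen with a group of another kind, such as an amine, a carboxylic acid or a longer alkyl chain. All three compounds also carry the thiourea and the trifluoromethyl-bearing phenyl, so the effect of a carbonyl in place of the thiocarbonyl, or of a nitrile in place of trifluoromethyl, remains unaddressed by these compounds.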